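This account rests on a few compounds, and the source may have more. Where it says the series, first, only, none or still open, it means among the compounds named here.

Measured compounds in a physicochemical assay for solubility, in phosphate buffer, at pH 7.4; a lower number here means a less soluble compound, a higher number a more soluble compound:
compound 1 `OC1CN(c2nccnc2OC2CN(c3ccc4ccccc4n3)C2)C1` gives 41000 nM;
compound 2 `NC(=O)C1CCN(c2nccnc2OC2CN(c3ccc4ccccc4n3)C2)CC1` gives 14000 nM;
compound 3 `OCc1cccc(-c2nccnc2OC2CN(c3ccc4ccccc4n3)C2)c1` gives 29000 nM.

Compound 1 stands highest of the three numbers. Its nearest neighbour is compound 3, with a 1.4-fold lower number from compound 1 to compound 3 (0.15 log units; within the scatter), a gap inside the usual scatter. The furthest is compound 2, with a 2.9-fold lower number from compound 1 to compound 2 (0.47 log units; beyond the scatter), a modest step beyond the scatter. Between the other two, a 2.1-fold higher number from compound 2 to compound 3 (0.32 log units; beyond the scatter), also a modest step.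

Compound 4 `N#Cc1ccc(-c2nccnc2OC2CN(c3ccc4ccccc4n3)C2)cc1` is not yet measured. Its difference from compound 1 is 4-cyanophenyl in place of 3-hydroxyazetidin-1-yl on an aromatic carbon.

Going by the values given here, two measured steps bear on this change. The step from compound 1 to compound 3 shows that putting a six-membered aromatic ring of carbon only in place of the 3-hydroxyazetidin-1-yl group, when that ring still carries a hydrogen-bond donor, left the number within the scatter. The step from compound 1 to compound 2 shows that a change of group at this aromatic carbon can move the number down modestly. Compound 4 carries no hydrogen-bond donor on the entering group, so a drop in this assay larger than that seen for compound 3 is expected, and compound 4 is expected to come in at 12000 nM, within 4000 nM to 30000 nM, meaning an expected step of a 3.4-fold lower number from compound 1 to compound 4 (0.53 log units; beyond the scatter).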

Compound 4, solubility: < 1000 nM
Compound 4 ended at the assay's limit; the forecaster's own chance of this, stated with the estimate: 5%; at least 12-fold (1.07 log units) between middle value and limit.
By their numbers in this assay, from the lowest: compound 2; then compounds 3 and 1 (each within the scatter of the next). At a limit, below all of these: compound 4.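

In this assay, compound 4 sits at a limit of the assay and not at a measured number: the limit of < 1000 nM in this assay, at which 1 of the 4 values shown sits.

This aromatic carbon, which the earlier compounds had shown only with a within-scatter or a modest step, can also carry a large one, and the 4-cyanophenyl group gives a large step against each of the other three groups: there is an at least 41-fold lower number from compound 1 to compound 4 (1.61 log units; beyond the scatter), an at least 14-fold lower number from compound 2 to compound 4 (1.14 log units; beyond the scatter) and an at least 29-fold lower number from compound 3 to compound 4 (1.46 log units; beyond the scatter). The last of these is the most telling, as the six-membered aromatic ring of carbon only is present on both sides of that step, so the presence of such a ring at this place does not by itself set the number.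

The compounds shown leave open whether the step goes with the nitrile itself, with where it sits on the ring, or with the absence of the hydroxymethyl group, since compound 3 and compound 4 differ in both the substituent and its place. On these data alone, an unsubstituted phenyl group, or a phenyl ring carrying an amine or a carboxylic acid where compound 4 has its nitrile, would bear on that, and how far compound 4 truly lies past the limit also stays unknown.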